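Cytotoxicity step from compound 2 to compound 4

The source may hold more compounds than are shown below. What is called first, only, known or untested is meant among the compounds shown, and "the series" means these compounds.

For the measured compounds named here, in an ADME assay on MT4 cells (Homo sapiens) for cytotoxicity, read by XTT assay, with a stated time of 5 days (a lower number here means that less compound is tolerated, a higher number that more compound is tolerated), compound 2 `COC(=O)N[C@H](C(=O)NN(CC[C@@](O)(Cc1ccccc1)C(=O)N[C@H]1c2ccccc2C[C@H]1O)Cc1ccc(-c2cccnc2)cc1)C(C)(C)C` gives 4900 nM, the only actual number in this small set. Compound 1 `COC(=O)N[C@H](C(=O)NN(CC[C@@](O)(Cc1ccccc1)C(=O)N[C@H]1c2ccccc2C[C@H]1O)Cc1ccc(-c2ccccc2)cc1)C(C)(C)C` reads > 10000 nM, which is a limit of the assay. Compound 3 `COC(=O)N[C@H](C(=O)NN(CC[C@@](O)(Cc1ccccc1)C(=O)N[C@H]1c2ccccc2C[C@H]1O)Cc1ccc(-c2cc(F)cc(F)c2)cc1)C(C)(C)C` reads > 10000 nM, also a limit. Compound 4 `COC(=O)N[C@H](C(=O)NN(CC[C@@](O)(Cc1ccccc1)C(=O)N[C@H]1c2ccccc2C[C@H]1O)Cc1ccc(-c2ccc(NC(C)=O)cc2)cc1)C(C)(C)C` carries 4-acetamidophenyl in place of pyridin-3-yl on an aromatic carbon, para to a large group: 4-acetamidophenyl in place of pyridin-3-yl on an aromatic carbon. Going by the values given here, two measured steps bear on this change: an at least 2.0-fold lower number from compound 1 to compound 2 (0.30 log units; that floor lies within the scatter) and an at least 2.0-fold higher number from compound 2 to compound 3 (0.30 log units; that floor lies within the scatter). Each is a floor within the scatter, and in both the higher side carries a ring of carbon only, as compound 4 does. Among the compounds with values here, a small upward move is therefore expected, with no step clearly beyond the scatter. The expected step is a 1.6-fold higher number from compound 2 to compound 4 (0.21 log units; within the scatter). The estimate for compound 4 is 8000 nM, with an expected range of 3500 nM to 15000 nM.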

Compound 4, half-maximal cytotoxic concentration: > 10000 nM
Compound 4: a limit, no number; the forecaster's own chance of this, stated with the estimate: 45%; at least 1.2-fold (0.09 log units) between middle value and limit.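

For the compounds shown here, at this position, para to a large group, this assay now has a ring of carbon only that carries an acetamido group, and replacing pyridin-3-yl with 4-acetamidophenyl gives an at least 2.0-fold higher number from compound 2 to compound 4 (0.30 log units; that floor lies within the scatter). The larger group, with one hydrogen-bond donor entering, therefore does not bring the number down to that of compound 2, although the floor of this step stays within the scatter. The steps to compound 1 and compound 3 cannot be read, as both sides are limits.

As far as these compounds go, whether an amine or a carboxylic acid on this outer ring would give a readable number remains open. The true size of each step also remains open: the limit of > 10000 nM in this assay, at which 3 of the 4 values shown sit.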